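Imidazolylbutyl on the pyrazole nitrogen of an inactive core

This account rests on a few compounds, and the source may have more. Where it says the series, first, only, none or still open, it means among the compounds named here.

This account follows one change made to compound 1, whose structure is `Cn1cc(C2=C(c3n[nH]c4ncccc34)C(=O)NC2=O)c2ccccc21`. In a functional assay on SMMC-7721 cells (Homo sapiens) for antiproliferative activity, read by MTT assay, with a stated time of 48 h (on this read-out higher numbers stand for weaker inhibition and lower numbers for stronger inhibition), compound 1 gives only a limit, > 100000 nM. Two related compounds are also known. Compound 2, `Cn1cc(C2=C(c3n[nH]c4ncccc34)C(=O)N(c3cccc4ccccc34)C2=O)c2ccccc21`, returns the same limit in this assay, > 100000 nM. Compound 3, `Cn1cc(C2=C(c3nn(CCCN4CCCCC4)c4ncccc34)C(=O)N(c3ccccn3)C2=O)c2ccccc21`, likewise reaches only a limit in this assay, > 100000 nM. Going by the values given here, the one step that can be traced, a step that the two limits leave unreadable from compound 1 to compound 2, is not readable because the limit of > 100000 nM in this assay, at which 3 of the 3 values shown sit, holds both of its ends at the same limit, so its size cannot be told.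

Compound 4, `Cn1cc(C2=C(c3nn(CCCCn4ccnc4)c4ncccc34)C(=O)NC2=O)c2ccccc21`, differs from compound 1 in one place: 4-(1H-imidazol-1-yl)butyl in place of hydrogen on an aromatic nitrogen. The group enters on an aromatic nitrogen of a five-membered aromatic ring with 2 nitrogen, part of a fused or bridged system of two rings. Among the compounds with values here, no measured step bears directly on this change; compound 3 carries a different chain on that same kind of nitrogen together with a second change, and it too sits at the limit. With every value at the limit, nothing indicates a movement beyond the scatter in either direction. Compound 4 is therefore expected to give a value of about 150000 nM in this assay, within a range from 30000 nM to 500000 nM, which would mean an estimated step that the limit leaves unreadable from compound 1 to compound 4, most likely reported as a limit once more.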

Compound 4, half-maximal inhibitory concentration: 29200 nM
Beside the measured number, compound 4's estimate is 5.1-fold (0.71 log units) above it; measured number outside the range, below it.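

In this assay, 4-(1H-imidazol-1-yl)butyl in place of hydrogen on the aromatic nitrogen gives an at least 3.4-fold lower number from compound 1 to compound 4 (0.53 log units; beyond the scatter), the only step shown whose direction can be read. This shows that, on the core of compound 1, this nitrogen can carry the chain with its five-membered aromatic ring and give a measured inhibition of these cells, which the compounds at the limit could not show. The size of this step remains a lower bound and the step to compound 2 cannot be read, because each has an end at a limit rather than a number: the limit of > 100000 nM in this assay, at which 3 of the 4 values shown sit.

The compounds shown do not separate the contribution of the imidazole ring from that of the butyl chain, a question that a plain butyl chain, or a morpholine at the end of the same chain, on the core of compound 1 would address. Going by these compounds, compound 3 differs from compound 4 in more than one place, so it gives no direct comparison, and how chain length affects the result stays open.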